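Amide side chain change from compound 1 to compound 4

The source may report more compounds than this note shows. Statements on the series, on what has been measured and on what is new or still open speak of the compounds shown alone.

In a physicochemical assay for lipophilicity, measured as octanol-water partition, at pH 7.4 (on this read-out higher numbers stand for higher lipophilicity and lower numbers for lower lipophilicity), compound 1 `Cc1ccc2[nH]c(C(=O)N[C@H]3CN(S(=O)(=O)c4ccccc4)C[C@@H]3C(=O)NCCN(C)C)cc2c1` gives 2.1 and its mirror image, compound 3 `Cc1ccc2[nH]c(C(=O)N[C@@H]3CN(S(=O)(=O)c4ccccc4)C[C@H]3C(=O)NCCN(C)C)cc2c1`, gives 2.1. These two share the highest of the three numbers, while compound 2 `Cc1ccc2[nH]c(C(=O)N[C@H]3CN(S(=O)(=O)C4CCOCC4)C[C@@H]3C(=O)NCCN(C)C)cc2c1` gives 1.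

The next structure is compound 4 `Cc1ccc2[nH]c(C(=O)N[C@H]3CN(S(=O)(=O)c4ccccc4)C[C@@H]3C(=O)N[C@@H]3CCCNC3)cc2c1`. The change is piperidin-3-yl in place of 2-(dimethylamino)ethyl on an amide-type nitrogen.

Within the data shown here, no measured step touches this place. The large step of a number 1.10 log units lower from compound 1 to compound 2 (beyond the scatter) comes with oxan-4-yl in place of phenyl on a sulfonyl sulfur, so it shows only how far one swap elsewhere moved the number. The step of no change at the digits printed from compound 1 to compound 3 (within the scatter) lies within the scatter and goes with the fact that compounds 1 and 3 differ only in the configuration as drawn, so the defined stereocentre of the entering group is not expected to weigh much.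

A moderate fall, smaller than the step to compound 2, is the working expectation. The expected step is a number 0.40 log units lower from compound 1 to compound 4 (beyond the scatter). For compound 4 the estimated value is 1.7, with an expected range of 1.1 to 2.3.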

Compound 4, distribution coefficient: 1.3
Estimate against measurement, compound 4: 0.40 log units above; measured number inside the range.
By their numbers in this assay, from the lowest: compounds 2 and 4 (each within the scatter of the next); then compounds 1 and 3 (each within the scatter of the next).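

In this assay, piperidin-3-yl in place of 2-(dimethylamino)ethyl on an amide-type nitrogen gives a number 0.80 log units lower from compound 1 to compound 4 (beyond the scatter), so the number responds at this position too, not only at the sulfonyl sulfur. This single change brings in one six-membered non-aromatic ring, one hydrogen-bond donor and one defined stereocentre together, so the step cannot be divided among them. Nothing measured here gives a cause for this step.

Open, on these data alone, is where the number would fall with 1-methylpiperidin-3-yl on the same amide-type nitrogen, which keeps the ring but carries no hydrogen-bond donor on the ring nitrogen. Also open, as far as these compounds go, is what a longer chain, such as 3-(dimethylamino)propyl, would give in the same place.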